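The compounds below may be only part of what the source reports. "The series", "measured", "known", "first", "only" and "open" are said of these compounds alone.

Measured compounds and their values in a functional assay on a cell-free system (plasma) with sterol O-acyltransferase, Soat (Rattus norvegicus) as the target; a higher number here means that more compound is needed for the effect, a lower number that less compound is needed

Compound 1 `Cc1cc(C)c(NC(=O)N(Cc2cccc(-c3nnnn3C)c2)C2CCCCCC2)c(C)c1` gives > 1 mg/kg in this assay, which is a limit of the assay and not a number.
Compound 2 `COc1ccccc1CN(Cc1cccc(-c2cc[nH]n2)c1)C(=O)Nc1c(SC)cc(C)nc1SC` gives > 0.1 mg/kg in this assay, again a limit rather than a number.
Compound 3 `O=C(Nc1c(F)cc(F)cc1F)N(Cc1ccc(-c2ccccn2)cc1)C1CCCCCC1` gives > 1 mg/kg in this assay, also a limit.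

Compound 1 therefore stands on a limit only, and the two further values shown are limits as well: the limit of > 1 mg/kg in this assay, at which 2 of the 3 values shown sit, and (the limit of > 0.1 mg/kg in this assay, at which 1 of the 3 values shown sits). Among the measured compounds shown here, no two of the measured compounds differ in a single place, so no measured step can be drawn, and nothing can be said about whether the three sit apart or together beyond what the limits themselves show.

Compound 4 `Cc1cc(C)c(NC(=O)N(Cc2cccc(-c3cn[nH]c3)c2)C2CCCCCC2)c(C)c1` is not yet measured. It differs from compound 1 in one place: 1H-pyrazol-4-yl in place of 1-methyl-1H-tetrazol-5-yl on an aromatic carbon. With compound 1 resting on a limit, no step size is anchored; the expected step from compound 1 to compound 4 a step that the limit leaves unreadable from compound 1 to compound 4 is taken as none beyond the scatter. Compound 4 is expected to give 2 mg/kg in this assay, within 0.5 mg/kg to 10 mg/kg, with a substantial chance that only a limit is reported again.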

Compound 4, dose for half-maximal effect: 0.19 mg/kg
For compound 4 the middle estimate is 11-fold (1.02 log units) above the measured one, outside the stated range (below it).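

In this assay, the aromatic carbon of the six-membered aromatic ring, meta to a large group, proves sensitive to the group it carries: 1H-pyrazol-4-yl in place of 1-methyl-1H-tetrazol-5-yl gives an at least 5.2-fold lower number from compound 1 to compound 4 (0.72 log units; beyond the scatter), with the rest of the structure unchanged. Compound 1 gives > 1 mg/kg, which is a limit of the assay and not a number, so the printed step is only a lower bound on its size. The entering ring carries a hydrogen-bond donor and the leaving ring none, but nothing measured ties the step to that difference or to any other.

The compounds shown leave open whether the ring hydrogen of 1H-pyrazol-4-yl matters, which 1-methyl-1H-pyrazol-4-yl at the same place would test, and whether a carboxylic acid or an amine would be tolerated there. As far as these compounds go, compound 2 and compound 3 differ from compound 4 in more than one place, so it also remains open whether the step would carry over to their other ureas.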